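The source may hold more compounds than are shown below. What is called first, only, known or untested is meant among the compounds shown, and "the series" means these compounds.

Measured compounds:

Compound 1, `ClCc1ccc(Cn2cnc3c(Cl)ncnc32)cc1`, in a functional assay on SF-539 cells (Homo sapiens) for cytotoxicity, read by sulforhodamine B assay, with a stated time of 48 h (on this read-out higher numbers stand for weaker inhibition of growth and lower numbers for stronger inhibition of growth), gives 1170 nM.
Compound 2, `ClCc1ccccc1Cn1cnc2nc(Cl)nc(Cl)c21`, in this assay gives 4260 nM.

Among the compounds with values here, compound 1 stands at the lowest of the two numbers so far in this assay; its nearest neighbour is compound 2, whose value lies beyond the usual scatter, so compound 1 shows the stronger growth inhibition of the pair. The two compounds differ in more than one place, so their values alone say nothing about any single change.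

Compound 3, `ClCc1ccc(Cn2cnc3c(Cl)nc(Cl)nc32)cc1`, has not yet been measured in this assay. It differs from compound 1 by a single change: chloro in place of hydrogen on an aromatic carbon. The new chloro sits on the core between two ring nitrogen atoms, meta to the chloro group already present.

Within the data shown here, no measured pair shows this change on its own, so its effect is open. A modest step is expected, more likely toward a weaker inhibition than toward a stronger one, and quite possibly not beyond the scatter. Compound 3 is estimated to give 1600 nM in this assay, within 600 nM to 4500 nM, which would mean a step of a 1.4-fold higher number from compound 1 to compound 3 (0.14 log units; within the scatter).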

Compound 3, concentration for total growth inhibition: 30900 nM
Compound 3: the middle estimate sits 19-fold (1.29 log units) below what was measured, and the stated range ends below it.
By their numbers in this assay, from the lowest: compound 1; then compound 2; then compound 3.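

In this assay, chloro in place of hydrogen on the aromatic carbon between two ring nitrogen atoms is a large step toward weaker inhibition of growth (a 26-fold higher number from compound 1 to compound 3 (1.42 log units; beyond the scatter)). Within the data shown here, this is the first sign that this position on the shared core matters in this assay: the change adds only one chlorine atom, with no ring, no net charge and no hydrogen-bond donors or acceptors, yet the step lies well beyond the scatter. Nothing available explains the loss, so the result records its size and place but gives no reason for it.

What the compounds shown leave open is whether the loss belongs to chloro specifically or would appear with any group on this carbon, since a single step cannot separate the two; an amine, a methoxy group or a methyl group here could tell them apart. It also remains open whether the same change has a step of similar size when the chloromethyl group sits elsewhere on the benzene ring, as no such pair of compounds is shown.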